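Swapping a hydroxyphenyl for a dimethylaminophenyl on the shared core

This account rests on a few compounds, and the source may have more. Where it says the series, first, only, none or still open, it means among the compounds named here.

Measured so far:
Compound 1, `Cc1cc(O)c(C2=NN(c3ccc(S(N)(=O)=O)cc3)C(c3ccccc3)C2)cc1Cl`, gives 60.3%.
Compound 2, `COc1cc(C)c(Cl)cc1C1=NN(c2ccc(S(N)(=O)=O)cc2)C(c2cccc(O)c2)C1`, gives 16.7%.

Both values come from a functional assay on the whole organism (strain Wistar) for inhibition, with Rattus norvegicus as the target, read by paw edema, with stated times of 30 min and 5 h, at a dose of 20 mg/kg by the oral route; a higher number here means more inhibition at the dose given (going by the name of the read-out), a lower number less inhibition. Among the two numbers, compound 2 stands lowest, and the gap to compound 1 lies beyond the scatter, so the inhibition of compound 2 in this assay is clearly the lower of the pair.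

Compound 3, `COc1cc(C)c(Cl)cc1C1=NN(c2ccc(S(N)(=O)=O)cc2)C(c2ccc(N(C)C)cc2)C1`, has not been measured. It keeps the core of compound 2 and differs in one place: 4-(dimethylamino)phenyl in place of 3-hydroxyphenyl on a saturated ring carbon

For the measured compounds named here, no step between two measured compounds isolates this change, so its effect is uncertain. Compound 1 shows that a different phenyl pattern on the shared core goes with a much higher number, which leaves room for a higher number here as well. Compound 3 is expected to give 30%, with a range of 10% to 55%. This expectation amounts to a moderate upward step, a number 13.3 percentage points higher from compound 2 to compound 3 (beyond the scatter), though the estimate range still overlaps with a step of no real change.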

Compound 3, a percentage reported as inhibition, in the whole organism at one dose (the size of the read-out at that dose, not a potency): 95.2%
Compound 3: the middle estimate sits 65.2 percentage points below what was measured; the whole stated range lies below it.
By their numbers in this assay, from the lowest: compound 2; then compound 1; then compound 3.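

In this assay, for the compounds shown here, the single swap of 3-hydroxyphenyl for 4-(dimethylamino)phenyl on the saturated ring carbon produces a number 78.5 percentage points higher from compound 2 to compound 3 (beyond the scatter), which the earlier pair could not show because compound 1 and compound 2 differ in more than one place. The group on this carbon can therefore, on its own, take the core of compound 2 from weak inhibition to the highest number of the series, with compound 3 at 95.2% in this whole-animal test. No measurement here explains why the swap has so large an effect.

From the compounds shown here alone, the step changes the substituent and its place on the phenyl ring together, so it remains open whether the dimethylamino group, its position or the loss of the hydroxyl matters most. Compounds carrying 3-(dimethylamino)phenyl or 4-hydroxyphenyl at this carbon would help separate these.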